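Carboxyl side chains on the shared core: compound 4

The source may hold more compounds than are shown below. What is called first, only, known or untested is meant among the compounds shown, and "the series" means these compounds.

Measured so far in a functional assay on HFL1 cells for antagonist activity at sphingosine 1-phosphate receptor 2 (Homo sapiens), read by ELISA, with a stated time of 24 h; a higher number here means a weaker inhibitor, a lower number a stronger inhibitor:
compound 1 `COC(C(=O)O)c1nn(Cc2cn3cc(OCC4CC4)c(Cl)cc3n2)c2ccccc2c1=O` gives 94 nM
compound 2 `O=C(O)C1(c2nn(Cc3cn4cc(OCC5CC5)c(Cl)cc4n3)c3ccccc3c2=O)CC1` gives 28 nM
compound 3 `CC(C)(C(=O)O)c1nn(Cc2cn3cc(OCC4CC4)c(Cl)cc3n2)c2ccccc2c1=O` gives 21 nM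

Compound 3 has the lowest number of the three, but compound 2 lies within the scatter of it (a 1.3-fold lower number from compound 2 to compound 3 (0.12 log units; within the scatter)); only compound 1 stands clearly apart (a 4.5-fold lower number from compound 1 to compound 3 (0.65 log units; beyond the scatter)). Compound 4 `CCC(C(=O)O)c1nn(Cc2cn3cc(OCC4CC4)c(Cl)cc3n2)c2ccccc2c1=O` is not yet measured. It differs from compound 3 in the side chain alone: 1-carboxypropyl in place of 1-carboxy-1-methylethyl on an aromatic carbon. Among the measured compounds shown here, the steps that bear on this part of the molecule are a 3.4-fold lower number from compound 1 to compound 2 (0.53 log units; beyond the scatter) and a 4.5-fold lower number from compound 1 to compound 3 (0.65 log units; beyond the scatter), both modest and both in one direction. Compound 4 keeps the carboxyl but changes the branching, a smaller change than either of those; no step beyond the scatter, or at most a modest rise in the number, is expected, that is a 1.9-fold higher number from compound 3 to compound 4 (0.28 log units; within the scatter). For compound 4 in this assay the estimate is 40 nM, between 15 nM and 120 nM.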

Compound 4, half-maximal inhibitory concentration: 5.6 nM
For compound 4 the middle estimate is 7.1-fold (0.85 log units) above the measured one, and the stated range ends above it.
By their numbers in this assay, from the lowest: compound 4; then compounds 3 and 2 (each within the scatter of the next); then compound 1.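

Joining the same side-chain atoms differently is enough to shift the number in this assay: 1-carboxypropyl in place of 1-carboxy-1-methylethyl gives a 3.8-fold lower number from compound 3 to compound 4 (0.57 log units; beyond the scatter) at this aromatic carbon. Against 1-carboxycyclopropyl the same group gives a 5.0-fold lower number from compound 2 to compound 4 (0.70 log units; beyond the scatter) on the shared core. Ethyl in place of methoxy on the saturated chain carbon gives a 17-fold lower number from compound 1 to compound 4 (1.22 log units; beyond the scatter) between two compounds at opposite ends of the series, so the group on that carbon matters.

Left open is how a longer chain such as 1-carboxybutyl, or an amide in place of the carboxylic acid, would behave here. Nothing shown gives a reason for these steps.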